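The compounds below may be only part of what the source reports. "The series", "measured", "known", "first", "only" and "open" are said of these compounds alone.

Working notes on the series. The shared core of compound 1 `OC(CCn1nc2c(Br)c(Br)c(Br)c(Br)c2n1)c1ccc(Br)cc1` is kept throughout, and the compounds differ only in what sits on the side chain. In a functional assay on CCRF-CEM cells (Homo sapiens) for antiproliferative activity, read by MTT assay, with a stated time of 48 h, tested at 100 uM (on this read-out higher numbers stand for a weaker effect at the one concentration tested and lower numbers for a stronger effect), compound 1 gives 0%. Compound 2 `OC(CCn1nc2c(Br)c(Br)c(Br)c(Br)c2n1)c1ccccc1`, the unsubstituted phenyl analogue, gives in this assay compound 2 0%. Compound 3 `C[C@@H](O)CCn1nc2c(Br)c(Br)c(Br)c(Br)c2n1` gives in this assay 24%.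

Within the data shown here, the one step measured, no change at the digits printed from compound 1 to compound 2 (within the scatter), is a removal of bromo from the aromatic ring and leaves the read-out where it was. Compound 2 therefore stands level with compound 1, the two together the lowest of the three numbers, while compound 3 stands higher than compound 2 by a margin beyond the scatter.

Compound 4 `OC(CCn1nc2c(Br)c(Br)c(Br)c(Br)c2n1)c1ccc(Cl)cc1` is the next member to be tested. Relative to compound 2 the difference is chloro in place of hydrogen on an aromatic carbon; read one bond further out it is phenyl to 4-chlorophenyl, so compound 4 carries a halogen on the aromatic carbon that in compound 1 carries bromo. Among the measured compounds shown here, the only step that bears on this is the bromo-to-hydrogen step, and it was flat. Because no change at the digits printed from compound 1 to compound 2 (within the scatter) showed nothing beyond the scatter, compound 4 is expected to give 2%, with a range of 0% to 12%. The expected step of a number 2 percentage points higher from compound 2 to compound 4 (within the scatter) is accordingly estimated as none beyond the scatter.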

Compound 4, a percentage reported as activity, at one concentration (the size of the read-out at that concentration, not a potency): 0%
Compound 4: the middle estimate sits 2 percentage points above what was measured; the range from low to high includes it.
By their numbers in this assay, from the lowest: compounds 1, 2 and 4 (each within the scatter of the next); then compound 3.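

In this assay the aromatic carbon para to a large group now has a third occupant on record, and chloro in place of hydrogen gives a step of its own (no change at the digits printed from compound 2 to compound 4 (within the scatter)), as does chloro in place of bromo (no change at the digits printed from compound 1 to compound 4 (within the scatter)). The flat result therefore no longer rests on a single pair: hydrogen, chloro and bromo at this place, on the otherwise unchanged side chain, cannot be told apart by this read-out, and the two halogens cannot be told apart from each other. No measurement in hand gives a reason for this flatness.

On these data alone, what remains open is whether a group other than a halogen on this aromatic carbon, such as an amine, a carboxylic acid or a methoxy group, would leave the read-out where it stands. As far as these compounds go, with all three compounds level at a single tested concentration, it also remains open whether any difference among hydrogen, chloro and bromo would appear at lower concentrations.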